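The compounds below may be only part of what the source reports. "The series", "measured", "known", "first", "only" and "open" are said of these compounds alone.

Compound 1 `COc1cc2c(cc1N1C[C@@H](C)N(C)[C@@H](C)C1)N(C(=O)c1cccc(Cl)c1Cl)CC2` gives 251 nM in an assay on isolated protein for binding affinity to 5-hydroxytryptamine receptor 1D (Homo sapiens) (on this read-out lower numbers stand for stronger inhibition and higher numbers for weaker inhibition), the highest of the three numbers in hand; compound 3 `COc1cc2c(cc1N1C[C@@H](C)N(C)[C@@H](C)C1)N(C(=O)c1ccc(-c3cccc(C)n3)c3ccccc13)CC2` gives 100 nM and compound 2 `COc1cc2c(cc1N1CCN(C)CC1)N(C(=O)c1ccc(-c3cccc(C)n3)c3ccccc13)CC2` gives 25.1 nM. Among the measured compounds shown here, the single step between measured compounds, a 4.0-fold higher number from compound 2 to compound 3 (0.60 log units; beyond the scatter), swaps the group on the other side of the shared core and leaves the (2,3-dichlorophenyl)carbonyl untouched, so no measured step bears on the change from compound 1 to compound 4 `COc1cc2c(cc1N1C[C@@H](C)N(C)[C@@H](C)C1)N(C(=O)c1cccc(Cl)c1)CC2`: hydrogen in place of chloro on an aromatic carbon. Lacking any step on that side, the account expects no movement beyond the scatter in this assay, and estimates compound 4 at 250 nM, in the range 100 nM to 630 nM, a step of a 1.0-fold lower number from compound 1 to compound 4 (0.00 log units; within the scatter).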

Compound 4, inhibition constant: 251 nM
Compound 4: middle estimate off by 1.0-fold (0.00 log units), on the low side; measured number inside the range.
By their numbers in this assay, from the lowest: compound 2; then compound 3; then compounds 1 and 4 (each within the scatter of the next).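

In this assay, hydrogen in place of chloro on an aromatic carbon, ortho to a chloro group and to a large group, gives no change at the digits printed from compound 1 to compound 4 (within the scatter). Among the compounds shown here, this is the first measured step on this side of the shared core, and it shows that (2,3-dichlorophenyl)carbonyl and (3-chlorophenyl)carbonyl read alike here, so this chloro is not required for the affinity seen. Nothing measured alongside these compounds explains why the number holds. As far as these compounds go, whether methoxy or an amino group on this aromatic carbon would read the same stays open, as does the outcome of replacing the remaining chloro with hydrogen.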